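The compounds below may be only part of what the source reports. "The series", "measured", "known", "first", "only" and "open" are said of these compounds alone.

Measured in a physicochemical assay for solubility, with a stated time of 24 h, at pH 4.5; on this read-out lower numbers stand for lower solubility and higher numbers for higher solubility:
- Compound 1 `O=C(NC[C@@H]1[C@H]2CN(C(=O)OCc3cc(Cl)cc(Cl)c3)C[C@@H]12)c1ccc2[nH]c(=O)oc2c1`: < 1 ug/mL (a limit)
- Compound 2 `Cc1ccc(COC(=O)N2C[C@@H]3[C@@H](CNC(=O)c4ccc5[nH]c(=O)oc5c4)[C@@H]3C2)nc1`: 66 ug/mL

Among the measured compounds shown here, compound 2, at 66 ug/mL, holds the only true number so far. Compound 1 gives < 1 ug/mL, which is a limit of the assay and not a number.

Compound 3 `Cc1cc(COC(=O)N2C[C@@H]3[C@@H](CNC(=O)c4ccc5[nH]c(=O)oc5c4)[C@@H]3C2)no1` puts 5-methyl-1,2-oxazol-3-yl in place of 5-methylpyridin-2-yl on a saturated chain carbon bound to an oxygen next to a carbonyl group.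

For the measured compounds named here, only one measured step bears on this: an at least 66-fold higher number from compound 1 to compound 2 (1.81 log units; beyond the scatter). That large step starts from the limit of < 1 ug/mL in this assay, at which 1 of the 2 values shown sits, and replaced a different group, so it is a weak guide here.

A slight fall, not beyond the scatter, is expected: a 1.5-fold lower number from compound 2 to compound 3 (0.17 log units; within the scatter). The estimate for compound 3 is 45 ug/mL, with an expected range of 12 ug/mL to 150 ug/mL.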

Compound 3, solubility: > 93 ug/mL
Compound 3: only a limit was reported; the forecaster's own chance of this, stated with the estimate: 10%; middle value at least 2.0-fold (0.31 log units) away from the limit.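

In this assay compound 3 gives > 93 ug/mL, which is a limit of the assay and not a number. As far as these compounds go, changing the six-membered ring to the five-membered ring gives an at least 1.4-fold higher number from compound 2 to compound 3 (0.14 log units; that floor lies within the scatter), so this position tolerates a second aromatic ring with two hetero atoms, with no fall seen, though the true size of the step stays unknown. Replacing the 3,5-dichlorophenyl group gives an at least 93-fold higher number from compound 1 to compound 3 (1.96 log units; beyond the scatter), and both ends of that step are limits.

The compounds shown leave open how far the read-out can go with this five-membered ring. They also leave open whether a non-aromatic group at this place, such as an amine or a longer chain, would hold it.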